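The compounds below may be only part of what the source reports. "The series", "measured", "known", "first", "only" and "open" are said of these compounds alone.

Working notes on the series.

Two members of this series have numbers in an assay on isolated protein for displacement of a labelled ligand from growth hormone secretagogue receptor type 1 (Homo sapiens), with a stated time of 1 h; on this read-out higher numbers stand for weaker inhibition and lower numbers for stronger inhibition. Compound 1, `CC(C)(N)C(=O)N[C@H](COCc1ccccc1)c1nnnn1CCCCC#N`, gives 3120 nM in this assay. Compound 2, `CC(C)(N)C(=O)N[C@H](COCc1ccccc1)c1nnn(Cc2ccccc2)n1`, gives 4750 nM in this assay. Among the compounds with values here, compound 2 carries the weaker-looking of the two figures, but its gap to compound 1 lies within the scatter of repeated measurements, so the two cannot be told apart on this pair alone, and no step between them is counted here.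

Compound 3, `CC(C)(N)C(=O)N[C@H](COCc1ccccc1)c1nnn(C/C=C/c2ccccc2)n1`, is the next member and has not yet been run in this assay. It differs from compound 2 at a single place: 2-phenylethenyl in place of phenyl on a saturated chain carbon bound to an aromatic nitrogen. Within the data shown here, no measured pair shows a change of this kind, so there is nothing to scale the step against; the two figures at hand move little between a nitrile-bearing chain and a benzyl group at this position, which gives no ground to expect a large shift in either direction.

The expected step from compound 2 to compound 3 is therefore a 1.2-fold lower number from compound 2 to compound 3 (0.07 log units; within the scatter), none beyond the scatter. Compound 3 is estimated at 4000 nM in this assay, with a range from 1500 nM to 12000 nM.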

Compound 3, inhibition constant: > 5000 nM
Compound 3: no number, only a limit (the forecaster's own chance of this, stated with the estimate: 5%); at least 1.2-fold (0.09 log units) between middle value and limit.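

The reading for compound 3 in this assay is a limit of the assay and not a number: the limit of > 5000 nM in this assay, at which 1 of the 3 values shown sits.

Within the data shown here, the one step that can be read is an at least 1.0-fold higher number from compound 2 to compound 3 (0.02 log units; that floor lies within the scatter), and it is only a floor, so its true size stays unknown. Among these compounds, this is the first measured change of this kind on a saturated chain carbon bound to an aromatic nitrogen: with 2-phenylethenyl in place of phenyl, and so with a double bond outside the aromatic ring, the read-out gives no sign of stronger inhibition, although it cannot show how much weaker compound 3 may be.

The compounds shown leave open how far compound 3 actually lies from compound 2, and whether any effect belongs to the double bond or to the longer chain, a question that a saturated 3-phenylpropyl group at this place would address. They also leave open how an amine or a carboxylic acid at the end of the chain would read out on the same core.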